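A nitro swap at the assay limit

This account rests on a few compounds, and the source may have more. Where it says the series, first, only, none or still open, it means among the compounds named here.

Compound 1 `COc1ccc(-c2cnc(NC(=O)c3cccnc3)n2C)cc1` – > 100000 nM (a limit)
Compound 2 `COc1ccc(-c2cnc(NC(=O)c3ccc(C)cc3)n2C)cc1` – > 100000 nM (a limit)
Compound 3 `COc1ccc(-c2cnc(NC(=O)c3ccccc3Br)n2C)cc1` – > 100000 nM (a limit)

In a toxicity assay on THP-1 cells (Homo sapiens) for inhibition (a higher number here means that more compound is tolerated, a lower number that less compound is tolerated), compound 2 stands at > 100000 nM as a limit and not a number. For the measured compounds named here, the series so far shows the limit of > 100000 nM in this assay, at which 3 of the 3 values shown sit, and no readable value. Compound 4 `COc1ccc(-c2cnc(NC(=O)c3ccc([N+](=O)[O-])cc3)n2C)cc1` follows from compound 2 by nitro in place of methyl on an aromatic carbon. The nearest measured steps, a step that the two limits leave unreadable from compound 1 to compound 2 and a step that the two limits leave unreadable from compound 2 to compound 3, give no size, so no change beyond the scatter is expected in this assay, in neither direction. The estimated step is a number no higher from compound 2 to compound 4 (the limit leaves the size open) and nothing larger is expected. Compound 4 is estimated at 100000 nM, expected to lie from 40000 nM to 200000 nM if a number is reported at all.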

Compound 4, half-maximal cytotoxic concentration: > 100000 nM
Compound 4: only a limit was reported; the forecaster's own chance of this, stated with the estimate: 80%; the middle value sits exactly at the limit.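

Compound 2 and compound 4 both give only a limit in this assay and so no new step can be read between them. The compounds shown leave open what concentration of any of them would be half-maximally cytotoxic.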